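Cycloheptyl on the carbonyl carbon: notes on the unbound fraction

The source may hold more compounds than are shown below. What is called first, only, known or untested is meant among the compounds shown, and "the series" means these compounds.

Of the compounds shown here, two sharing one core have been measured in an ADME assay for protein binding, using equilibrium dialysis, at pH 7.4, tested at 2 uM; a lower number here means a smaller unbound share, a higher number a larger unbound share of the compound. Compound 1 `CC(C)N(c1cc(C#CC(C)(C)C)sc1C(=O)O)C(=O)[C@H]1CC[C@H](C)CC1` gives 0.06. Compound 2 `CC(C)N(C(=O)[C@H]1CC[C@@H]2C[C@@H]2CC1)c1cc(C#CC(C)(C)C)sc1C(=O)O` gives 0.08, the higher of the two numbers, though the pair lies within the scatter, so compound 2 cannot be separated from compound 1.

Compound 3 `CC(C)N(C(=O)C1CCCCCC1)c1cc(C#CC(C)(C)C)sc1C(=O)O` differs from compound 2 by one change: a group of 7 heavy atoms (7 carbon; one seven-membered non-aromatic ring of carbon only) in place of a group of 8 heavy atoms (8 carbon; one three-membered non-aromatic ring of carbon only, one seven-membered non-aromatic ring of carbon only), on a carbonyl carbon. It sits on a carbonyl carbon whose other neighbours are: amide-type nitrogen. The three-membered ring goes, and cycloheptyl keeps the seven-membered ring.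

For the measured compounds named here, only one measured step bears on this change: a 1.3-fold higher number from compound 1 to compound 2 (0.12 log units; within the scatter). That step also exchanged one all-carbon ring group for another at the same place, and it stayed within the scatter. One step is thin evidence, and the data do not settle a direction. No shift beyond the scatter is therefore expected in this assay. The expected step is a 1.1-fold lower number from compound 2 to compound 3 (0.06 log units; within the scatter). For compound 3 the estimated value is 0.07, with an estimated range of 0.04 to 0.12.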

Compound 3, unbound fraction: 0.11
For compound 3 the middle estimate is 1.6-fold (0.20 log units) below the measured one; measured number inside the range.
By their numbers in this assay, from the lowest: compounds 1, 2 and 3 (each within the scatter of the next).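

At this position, on a carbonyl carbon whose other neighbour is an amide-type nitrogen, the measurements in this assay now cover three all-carbon ring groups: cycloheptyl in place of the group with the three-membered and seven-membered rings gives a 1.4-fold higher number from compound 2 to compound 3 (0.14 log units; within the scatter), and cycloheptyl in place of 4-methylcyclohexyl gives a 1.8-fold higher number from compound 1 to compound 3 (0.26 log units; within the scatter). Compound 1 and compound 2 alone offered a single step, whereas every pair among the three compounds can now be read, and none of the steps leaves the scatter, so the three groups cannot be separated by their unbound fraction in this set, even with the three-membered ring removed from the seven-membered ring. Nothing at hand explains the size or direction of these small steps.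

The compounds shown leave open whether any group on this carbonyl carbon can move the unbound fraction beyond the scatter, since all three groups are made of carbon alone, and a ring carrying an amine or a hydroxyl group might behave differently. An open longer chain at the same place also remains an untested comparison with these ring groups.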